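Swapping fluoro for methyl on the benzamide ring

This account rests on a few compounds, and the source may have more. Where it says the series, first, only, none or still open, it means among the compounds named here.

Measured compounds:
compound 1 `CCN(CC)CCNc1cc(C)c2cc(NC(=O)c3ccc(Cl)c(Cl)c3)ccc2n1` — 3710 nM
compound 2 `CCN1CCN(c2cc(C)c3cc(NC(=O)c4cccc(F)c4)ccc3n2)CC1` — 24900 nM
compound 3 `Cc1cc(NCCN2CCCCC2)nc2ccc(NC(=O)c3ccc(Cl)c(Cl)c3)cc12` — 1800 nM

Of the compounds shown here, three sharing one core have been tested in a functional assay on SK-BR-3 cells (Homo sapiens) for antiproliferative activity, read by MTT assay, with a stated time of 72 h; on this read-out lower numbers stand for stronger inhibition and higher numbers for weaker inhibition. Compound 1 gives 3710 nM in this assay, compound 3 gives 1800 nM, and compound 2 gives 24900 nM, the highest number of the three and therefore the weakest inhibitor of the set.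

The unmeasured compound 4 `CCN1CCN(c2cc(C)c3cc(NC(=O)c4cccc(C)c4)ccc3n2)CC1` is compound 2 with one change: methyl in place of fluoro on an aromatic carbon. Within the data shown here, the single measured step, a 2.1-fold lower number from compound 1 to compound 3 (0.31 log units; beyond the scatter), concerns the amine on the side chain and not the benzamide ring, so no measured step bears on the change from compound 2 to compound 4. With nothing in the data to point either way, the expectation for compound 4 in this assay is a number close to that of compound 2, with a step no larger than a 1.2-fold lower number from compound 2 to compound 4 (0.10 log units; within the scatter) and likely within the scatter. Compound 4 is therefore estimated at 20000 nM, in the range 7000 nM to 60000 nM.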

Compound 4, half-maximal inhibitory concentration: 13700 nM
The estimate for compound 4 lay 1.5-fold (0.16 log units) above the measured number; the range from low to high includes it.
By their numbers in this assay, from the lowest: compound 3; then compound 1; then compounds 4 and 2 (each within the scatter of the next).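

In this assay, methyl in place of fluoro on this aromatic carbon, meta to a large group, gives a 1.8-fold lower number from compound 2 to compound 4 (0.26 log units; within the scatter), so the assay cannot tell compound 2 and compound 4 apart. Among these compounds, this is the first measured change on the benzamide ring, as the earlier step concerned only the amine on the side chain, and it shows that these two single-atom-sized groups are interchangeable here as far as this read-out can show. No measured evidence accompanies this result to explain it.

From the compounds shown here alone, whether a group of another kind at this position, such as an amine, a carboxylic acid or a longer chain, would move the number beyond the scatter remains open. Also open, going by these compounds, is whether the same swap would behave alike in compounds carrying the piperidin-1-yl or diethylamino side chain.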